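This account rests on a few compounds, and the source may have more. Where it says the series, first, only, none or still open, it means among the compounds named here.

In a functional assay on PC-3 cells (Homo sapiens) for cytotoxicity, read by sulforhodamine B assay, with a stated time of 48 h (a higher number here means a weaker inhibitor, a lower number a stronger inhibitor), compound 1 (`C[C@H]1CC[C@@H]2[C@@H](OC(=O)[C@]23CC(c2ccc(N(C)C)cc2)=NO3)[C@]2(C)C(=O)C=C[C@@]12O`) gives 6300 nM as its value, compound 2 (`C[C@H]1CC[C@@H]2[C@@H](OC(=O)[C@]23CC(c2ccc([N+](=O)[O-])cc2)=NO3)[C@]2(C)C(=O)C=C[C@@]12O`) gives 12000 nM and compound 3 (`COc1ccc(C2=NO[C@]3(C2)C(=O)O[C@@H]2[C@H]3CC[C@H](C)[C@]3(O)C=CC(=O)[C@@]23C)cc1OC`) gives 25000 nM as the highest of the three numbers. Next comes compound 4 (`COc1cc(C2=NO[C@]3(C2)C(=O)O[C@@H]2[C@H]3CC[C@H](C)[C@]3(O)C=CC(=O)[C@@]23C)ccc1O`), with hydrogen in place of methyl on an oxygen on an aromatic ring, which turns 3,4-dimethoxyphenyl into 4-hydroxy-3-methoxyphenyl. Among the compounds with values here, no measured step makes this exact change. The nearest evidence lies in swaps of the aromatic group, where (a 2.1-fold higher number from compound 2 to compound 3 (0.32 log units; beyond the scatter)) and (a 4.0-fold higher number from compound 1 to compound 3 (0.60 log units; beyond the scatter)) are both modest and (a 1.9-fold higher number from compound 1 to compound 2 (0.28 log units; within the scatter)) stays within the scatter. Given those sizes, a small step is expected in this assay with a lean toward a lower number, as compound 3 already sits at 25000 nM at the top of the series. The estimated step is (a 1.6-fold lower number from compound 3 to compound 4 (0.19 log units; within the scatter)) and no step beyond the scatter is counted on. Compound 4 is estimated at 16000 nM with an expected range from 6000 nM to 45000 nM for this measurement.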

Compound 4, half-maximal inhibitory concentration: 16000 nM
Beside the measured number, compound 4's estimate shows no gap at the digits printed; measured number inside the range.
By their numbers in this assay, from the lowest: compounds 1, 2, 4 and 3 (each within the scatter of the next, the first and the last beyond it).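

In this assay, exchanging methyl for hydrogen on an oxygen on an aromatic ring, with the rest of the aromatic group kept, gives a 1.6-fold lower number from compound 3 to compound 4 (0.19 log units; within the scatter), so methoxy and hydroxy at this place are not told apart in this series. The 4-hydroxy-3-methoxyphenyl group likewise cannot be separated from 4-nitrophenyl, with a 1.3-fold higher number from compound 2 to compound 4 (0.12 log units; within the scatter), whereas against 4-(dimethylamino)phenyl it gives a 2.5-fold higher number from compound 1 to compound 4 (0.40 log units; beyond the scatter), a gap of the same direction as the one already seen for 3,4-dimethoxyphenyl. No measurement at hand explains the size of any of these steps.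

Open, from the compounds shown here alone, is what an amine or a carboxylic acid on the aromatic ring would give in place of the hydroxy. Also open, going by these compounds, is whether the hydroxy reads the same without the methoxy still on the ring, as a plain 4-hydroxyphenyl group.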